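The compounds below may be only part of what the source reports. "The series", "measured", "known", "first", "only" and "open" are said of these compounds alone.

Compound 1 `O=C(Nc1nc2ccc(-c3cccc(CO)c3)cc2s1)c1ccc(F)cc1Cl` gives 28500 nM in a functional assay on A549 cells (Homo sapiens) for inhibition, read by MTT assay, with a stated time of 72 h; on this read-out higher numbers stand for weaker inhibition and lower numbers for stronger inhibition.
Compound 2 `O=C(Nc1nc2ccc(-c3cccc(CO)c3)cc2s1)c1ccccc1Br` gives 18100 nM in this assay.

Only these two compounds have been measured in this assay. Within the data shown here, the single step between them, a 1.6-fold lower number from compound 1 to compound 2 (0.20 log units; within the scatter), lies within the scatter, so the two numbers cannot be told apart. Compound 2 shows the lower of the two numbers, with compound 1 nearest, but this does not amount to a difference in potency.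

Compound 3 `Cc1cc(C)c(C(=O)Nc2nc3ccc(-c4cccc(CO)c4)cc3s2)o1` has not yet been measured in this assay. It differs from compound 2 in 3,5-dimethylfuran-2-yl in place of 2-bromophenyl on a carbonyl carbon. Among the measured compounds shown here, no measured step bears directly on this change: the one step available, a 1.6-fold lower number from compound 1 to compound 2 (0.20 log units; within the scatter), swaps one substituted phenyl for another and stays within the scatter, and nothing measured here carries a furan in this position. With no step beyond the scatter anywhere in the measured set, compound 3 is expected to remain close to compound 2.

The step expected from compound 2 to compound 3 is a 1.1-fold higher number from compound 2 to compound 3 (0.04 log units; within the scatter), which is estimated to stay within the scatter. Compound 3 is therefore estimated at 20000 nM in this assay, with a range from 6000 nM to 65000 nM.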

Compound 3, half-maximal inhibitory concentration: 55200 nM
Compound 3: the middle estimate sits 2.8-fold (0.44 log units) below what was measured, within the range that was stated.
By their numbers in this assay, from the lowest: compounds 2, 1 and 3 (each within the scatter of the next, the first and the last beyond it).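

In this assay this place on the carbonyl carbon gives its first step beyond the scatter: 3,5-dimethylfuran-2-yl in place of 2-bromophenyl yields a 3.0-fold higher number from compound 2 to compound 3 (0.48 log units; beyond the scatter) and so, though the change is modest, the group held here is not freely interchangeable. The same furan in place of 2-chloro-4-fluorophenyl yields a 1.9-fold higher number from compound 1 to compound 3 (0.29 log units; within the scatter) and those two numbers cannot be told apart, so the separation appears against only one of the two substituted phenyl groups. Nothing available accounts for why the furan separates from the 2-bromophenyl group.

As far as these compounds go, all three compounds carry an aromatic ring on this carbonyl carbon, so what an open alkyl chain, an amine or a carboxylic acid would do there remains open. Whether the step follows the ring oxygen or the two methyl groups of the furan also remains open: neither a furan-2-yl without methyl groups nor an unsubstituted phenyl is among the compounds shown.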